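Swapping the Ethoxyethyl Arm for Cyclohexyl on the Amine

A few compounds are considered here, and "the series" means these few. Any claim that something is new, unique, unknown or untested is made for them only; others in the source may bear on it.

Measured compounds:
compound 1, `COc1cccc(-n2cc3nc(-c4cccnc4C)n(C[C@H]4CCCN(CC5CCOC5)C4)c(=O)c3n2)c1`: 60 nM
compound 2, `CCO[C@H](C)CN1CCC[C@H](Cn2c(-c3cccnc3C)nc3cn(-c4cccc(OC)c4)nc3c2=O)C1`: 40 nM
compound 3, `CCO[C@@H](C)CN1CCC[C@H](Cn2c(-c3cccnc3C)nc3cn(-c4cccc(OC)c4)nc3c2=O)C1`: 5 nM

All three share one core and differ only in the group on a saturated chain carbon bound to an amine nitrogen in a ring. In an assay on HEK293 cells for displacement of a labelled ligand from growth hormone secretagogue receptor type 1 (Homo sapiens), with a stated time of 60 min (a lower number here means a stronger inhibitor, a higher number a weaker inhibitor), compound 3 stands lowest of the three, with a 12-fold lower number from compound 1 to compound 3 (1.08 log units; beyond the scatter) and an 8.0-fold lower number from compound 2 to compound 3 (0.90 log units; beyond the scatter), both beyond the scatter. The second of these steps can be read as a pure effect of the drawn configuration because of the fact that compounds 2 and 3 differ only in the configuration as drawn. By contrast, a 1.5-fold lower number from compound 1 to compound 2 (0.18 log units; within the scatter) stays within the scatter.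

Compound 4, `COc1cccc(-n2cc3nc(-c4cccnc4C)n(C[C@H]4CCCN(CC5CCCCC5)C4)c(=O)c3n2)c1`, has not yet been measured. It differs from compound 3 in this way: cyclohexyl in place of 1-ethoxyethyl on a saturated chain carbon bound to an amine nitrogen in a ring. Within the data shown here, the steps that bear on this change are the two leading to compound 3, and they point the same way: the oxolan-3-yl ring in compound 1 and the R-drawn chain in compound 2 both sit well above compound 3. Compound 4 carries a ring again, without the oxygen and without the stereocentre, so a return toward the level of compound 1 is expected, an 8.0-fold higher number from compound 3 to compound 4 (0.90 log units; beyond the scatter). Compound 4 is estimated at 40 nM, within 10 nM to 160 nM.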

Compound 4, half-maximal inhibitory concentration: 200 nM
The estimate for compound 4 lay 5.0-fold (0.70 log units) below the measured number, and the stated range ends below it.
By their numbers in this assay, from the lowest: compound 3; then compounds 2 and 1 (each within the scatter of the next); then compound 4.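

In this assay, cyclohexyl gives the highest number of the four: measured against the two 1-ethoxyethyl compounds, there is a 40-fold higher number from compound 3 to compound 4 (1.60 log units; beyond the scatter) and a 5.0-fold higher number from compound 2 to compound 4 (0.70 log units; beyond the scatter) at this position. Having a ring here is not enough to hold the level of compound 1, as the change from oxolan-3-yl to a ring of carbon only gives a 3.3-fold higher number from compound 1 to compound 4 (0.52 log units; beyond the scatter) in the same place. All three compounds with an oxygen in this group have lower numbers than compound 4, the only one without it, but no measurement shown explains this gap.

From the compounds shown here alone, the oxygen and the ring size change together between compound 1 and compound 4, so their separate contributions remain open. An oxan-4-yl group, a six-membered ring containing oxygen, and a cyclopentyl group, a five-membered ring of carbon only, would pull them apart.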